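This account rests on a few compounds, and the source may have more. Where it says the series, first, only, none or still open, it means among the compounds named here.

Compound 1 `COc1cc2c(cc1OC)C(CC(=O)O)CC2` is the parent of the pair; in a functional assay on the whole organism (strain Wistar) for inhibition, with Rattus norvegicus as the target, read by paw edema, with a stated time of 1 h, at a dose of 100 mg/kg (a higher number here means more inhibition at the dose given (going by the name of the read-out), a lower number less inhibition), compound 1 gives 18.8%, the lower of the two numbers measured. Compound 2 `COc1cc2c(cc1OC)C(CC(=O)Nc1cccc(Cl)c1)CC2` carries (3-chlorophenyl)amino in place of hydroxy on the carbonyl carbon, and in this assay compound 2 gives 31.3%, a step of a number 12.5 percentage points higher from compound 1 to compound 2 (beyond the scatter). Compound 3 `COc1cc2c(cc1OC)C(CC(=O)Nc1ccccc1C)CC2` is built as (2-methylphenyl)amino in place of hydroxy on a carbonyl carbon. Within the data shown here, the only step on record that bears on it is that from compound 1 to compound 2, modest and beyond the scatter, so a rise of similar size is expected, a number 11.2 percentage points higher from compound 1 to compound 3 (beyond the scatter). Compound 3 is therefore estimated at 30%, within 18% to 42%.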

Compound 3, a percentage reported as inhibition, in the whole organism at one dose (the size of the read-out at that dose, not a potency): 21.9%
The estimate for compound 3 lay 8.1 percentage points above the measured number; measured number inside the range.
By their numbers in this assay, from the lowest: compounds 1, 3 and 2 (each within the scatter of the next, the first and the last beyond it).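

In this assay, the step with (2-methylphenyl)amino in place of hydroxy is a number 3.1 percentage points higher from compound 1 to compound 3 (within the scatter) and so does not repeat the rise beyond the scatter seen for compound 2; replacing hydroxy with an aryl amide therefore does not by itself raise the number beyond the scatter. The swap of 3-chlorophenyl for 2-methylphenyl on the amide-type nitrogen is a number 9.4 percentage points lower from compound 2 to compound 3 (within the scatter) and leaves these two amides unseparated. No available evidence bears on this result.

The two aryl groups differ in both substituent and its place, so neither can be singled out. On these data alone, how a benzylamino or morpholine group on the carbonyl carbon would read remains open.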